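Methyl for Methoxy on the Fused Ring of Compound 3

The compounds below may be only part of what the source reports. "The series", "measured", "known", "first", "only" and "open" are said of these compounds alone.

Compound 3 `COc1ccc2nc(NC(=O)c3cn(-c4ccccc4)nc3-c3ccc(F)cc3)sc2c1` stands at the edge of what is known. In a functional assay on A549 cells (Homo sapiens) for cytotoxicity, read by MTT assay, with a stated time of 72 h (on this read-out lower numbers stand for stronger inhibition and higher numbers for weaker inhibition), compound 3 gives > 50000 nM, which is a limit of the assay rather than a number (the limit of > 50000 nM in this assay, at which 1 of the 3 values shown sits). Within the data shown here, compound 2 `O=C(Nc1nc2ccc(F)cc2s1)c1cn(-c2ccccc2)nc1-c1ccc(F)cc1` gives 6650 nM in this assay, and an at least 7.5-fold higher number from compound 2 to compound 3 (0.87 log units; beyond the scatter) is the only measured step involving the methoxy group. Compound 1 `Cc1ccc2nc(NC(=O)c3cn(-c4ccccc4)nc3-c3ccccc3)sc2c1`, which carries a methyl on the fused ring and an unsubstituted phenyl, gives 26500 nM in this assay. Compound 4 `Cc1ccc2nc(NC(=O)c3cn(-c4ccccc4)nc3-c3ccc(F)cc3)sc2c1` differs from compound 3 by methyl in place of methoxy on an aromatic carbon. Among the measured compounds shown here, no measured step sets methyl against methoxy directly. Because the measured step of an at least 7.5-fold higher number from compound 2 to compound 3 (0.87 log units; beyond the scatter) was large, its reversal is expected to lower the number, an expected step of an at least 2.5-fold lower number from compound 3 to compound 4 (0.39 log units; beyond the scatter). Compound 4 is therefore estimated at 20000 nM, with a range from 6000 nM to 60000 nM.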

Compound 4, half-maximal inhibitory concentration: 24600 nM
Beside the measured number, compound 4's estimate is 1.2-fold (0.09 log units) below it; low and high end bracket the measured number.
By their numbers in this assay, from the lowest: compound 2; then compounds 4 and 1 (each within the scatter of the next). At a limit, above all of these: compound 3.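

Compound 3 remains a limit of the assay in this assay, not a number: the limit of > 50000 nM in this assay, at which 1 of the 4 values shown sits. Methyl at this position gives a measured value, but the step of an at least 2.0-fold lower number from compound 3 to compound 4 (0.30 log units; that floor lies within the scatter) is only a floor. Methyl gives a weaker result than fluoro at this position, with a 3.7-fold higher number from compound 2 to compound 4 (0.57 log units; beyond the scatter), while fluoro in place of hydrogen on an aromatic carbon, with methyl held fixed, gives a 1.1-fold lower number from compound 1 to compound 4 (0.03 log units; within the scatter).

Going by these compounds, the true size of the step from methoxy to methyl stays open. So does whether an amine or a chloro group at this position would give a lower number than fluoro.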